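Pyridinyl amide in a hydroxy-pyridone series for paw edema

The source may report more compounds than this note shows. Statements on the series, on what has been measured and on what is new or still open speak of the compounds shown alone.

Of the compounds shown here, two sharing one core have been measured in a functional assay on the whole organism for inhibition, with Rattus norvegicus as the target, read by paw edema, at a dose of 100 mg/kg by the oral route; on this read-out lower numbers stand for less inhibition and higher numbers for more inhibition at the one dose given (going by the name of the read-out). Compound 1, with the structure `CCOC(=O)c1c(O)c2cccnc2n(-c2ccccc2)c1=O`, gives 23.5%. Compound 2, with the structure `Cc1ccccc1NC(=O)c1c(O)c2cccnc2n(-c2ccccc2)c1=O`, gives 11.7%. Among the compounds with values here, the single step between them, a number 11.8 percentage points lower from compound 1 to compound 2 (beyond the scatter), shows the amide of compound 2 standing lower than the ester of compound 1, and compound 2 therefore sits at the lower of the two numbers so far.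

Compound 3, with the structure `O=C(Nc1cccnc1)c1c(O)c2cccnc2n(-c2ccccc2)c1=O`, has not yet been measured. Its change from compound 2 is pyridin-3-yl in place of 2-methylphenyl on an amide-type nitrogen. Within the data shown here, no measured step covers an exchange of this kind: the one known step swaps an ethoxy for an amino group on the carbonyl carbon, not one aryl ring for another on the amide nitrogen. With nothing to show that the aryl ring on the nitrogen moves the read-out, the expected step is a number 1.3 percentage points higher from compound 2 to compound 3 (within the scatter), a change not expected to exceed the scatter. Compound 3 is therefore estimated at 13%. The range for compound 3 is expected to run from 2% to 28%.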

Compound 3, a percentage reported as inhibition, in the whole organism at one dose (the size of the read-out at that dose, not a potency): 30.3%
The estimate for compound 3 lay 17.3 percentage points below the measured number; measured number outside the range, above it.
By their numbers in this assay, from the lowest: compound 2; then compounds 1 and 3 (each within the scatter of the next).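

In this assay, within the data shown here, the ring on the amide-type nitrogen proves able to move the read-out: pyridin-3-yl in place of 2-methylphenyl gives a number 18.6 percentage points higher from compound 2 to compound 3 (beyond the scatter) and so shows a change beyond the scatter at this position, which the one earlier step, made on the carbonyl carbon, could not show. The amide link alone therefore does not fix the read-out at the low number of compound 2, for (pyridin-3-yl)amino in place of ethoxy on the carbonyl carbon gives a number 6.8 percentage points higher from compound 1 to compound 3 (within the scatter) and leaves compound 1 and compound 3 level within the scatter. Nothing available here accounts for the effect of the ring exchange.

Still open, on these data alone, is whether the step belongs to the ring nitrogen that enters or to the methyl group that leaves, as the exchange changes both at once and only a plain phenyl on the amide nitrogen would separate the two. Also open, as far as these compounds go, is how a pyridin-4-yl or pyridin-2-yl ring on that nitrogen would read at this one dose, and whether a read-out of this size holds at other doses.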